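The compounds below may be only part of what the source reports. "The series", "measured", "known", "first", "only" and "open" are said of these compounds alone.

Measured so far in an ADME assay (liver) for metabolic stability, with Liver microsome (Homo sapiens) as the target, read by LC-MS, using microsomes and NADPH, with a stated time of 5 min, at 37 degrees C; on this read-out lower numbers stand for slow clearance and higher numbers for fast clearance:

compound 1, `CCn1c(C(C)NS(=O)(=O)c2ccc(Cl)cc2)nc2cccnc21`, gives 94 mL.min-1.g-1
compound 2, `CCn1c(C(C)NS(=O)(=O)c2ccc(Cl)cc2)nc2ccncc21`, gives 93 mL.min-1.g-1
compound 3, `CCn1c([C@@H](C)NS(=O)(=O)c2ccc(F)cc2)nc2ccc(C(F)(F)F)cc21`, gives 26 mL.min-1.g-1

Compound 3 has the lowest of the three numbers in this assay. Its nearest neighbour is compound 2, whose value sits higher, and compound 1 sits at almost the same distance; both gaps lie beyond the usual scatter of this read-out. Compound 3 is therefore the slowest-cleared of the set, while compounds 1 and 2 are not ordered against each other.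

Compound 4, `CCn1c([C@@H](C)NS(=O)(=O)c2cnc(C)n2C)nc2ccc(C(F)(F)F)cc21`, has not yet been run in this assay. It is compound 3 with one change: 1,2-dimethyl-1H-imidazol-5-yl in place of 4-fluorophenyl on a sulfonyl sulfur. For the measured compounds named here, no pair among the measured compounds shows what such a swap does on this read-out, and compounds 1 and 2 differ from compound 3 in the core as well as in the ring on the sulfonyl sulfur, so they give no direct guide.

Given the value of compound 3 in this assay, 26 mL.min-1.g-1, and the absence of any comparable step, the expected step of a 1.0-fold lower number from compound 3 to compound 4 (0.02 log units; within the scatter) is none beyond the scatter, with wide uncertainty in either direction. Compound 4 is thus estimated at 25 mL.min-1.g-1, in the range 10 mL.min-1.g-1 to 60 mL.min-1.g-1.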

Compound 4, intrinsic clearance in microsomes: 58 mL.min-1.g-1
Compound 4: the middle estimate sits 2.3-fold (0.37 log units) below what was measured; the range from low to high includes it.
By their numbers in this assay, from the lowest: compound 3; then compounds 4, 2 and 1 (each within the scatter of the next).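

In this assay, for the compounds shown here, 1,2-dimethyl-1H-imidazol-5-yl in place of 4-fluorophenyl on a sulfonyl sulfur gives a 2.2-fold higher number from compound 3 to compound 4 (0.35 log units; beyond the scatter), the first comparison that changes a single place. This shows that, with the rest of compound 3 held constant, the ring on the sulfonyl sulfur can alone shift the read-out by a modest step beyond the usual scatter. The two groups match in heavy-atom count and differ in ring size, ring atoms and hydrogen-bond acceptors, but no measurement available here separates these differences or links the step to a property of either ring.

One step at one position gives no trend, and the compounds shown do not reveal which feature of the 1,2-dimethyl-1H-imidazol-5-yl group goes with the higher number, nor whether the same swap gives a similar step on the core of compound 1 or compound 2. A pyridin-3-yl ring, a 1-methyl-1H-imidazol-5-yl ring with one methyl fewer, or a cyclopropyl group on the sulfonyl sulfur would extend this single comparison and help separate ring type from substitution.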